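Pyridyl nitrogen shift at the amide nitrogen

The source may hold more compounds than are shown below. What is called first, only, known or untested is meant among the compounds shown, and "the series" means these compounds.

The three measured compounds share one core and differ only in the aryl group carried on the amide-type nitrogen. In an assay on cytosol from placenta for inhibition of 17-beta-hydroxysteroid dehydrogenase type 2 (Homo sapiens), read by HPLC, using microsomes, with a stated time of 10 min, in the presence of a further agent that is not named here (on this read-out lower numbers stand for stronger inhibition and higher numbers for weaker inhibition), compound 1 `Cc1cccc(F)c1N(C)C(=O)c1ccc(-c2ccc(O)cc2)o1` gives 3200 nM, and compound 2 `Cc1cc(F)ccc1N(C)C(=O)c1ccc(-c2ccc(O)cc2)o1` gives 1700 nM, the two lying within the scatter of each other: a 1.9-fold lower number from compound 1 to compound 2 (0.27 log units; within the scatter). In this assay compound 3 `Cc1cccnc1N(C)C(=O)c1ccc(-c2ccc(O)cc2)o1` gives only a limit of the assay, > 10000 nM. What is known of compound 3 is thus confined to the limit of > 10000 nM in this assay, at which 1 of the 3 values shown sits, and the steps onto it are bounds: an at least 3.1-fold higher number from compound 1 to compound 3 (0.49 log units; beyond the scatter) and an at least 5.8-fold higher number from compound 2 to compound 3 (0.76 log units; beyond the scatter).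

Compound 4 `Cc1ccncc1N(C)C(=O)c1ccc(-c2ccc(O)cc2)o1` is not yet measured. It differs from compound 3 by 4-methylpyridin-3-yl in place of 3-methylpyridin-2-yl on an amide-type nitrogen. Among the measured compounds shown here, no measured step moves the ring nitrogen within a pyridyl group; the only steps at this position exchange a fluorinated methylphenyl for a pyridyl, and both of them run to higher numbers in this assay. For the measured compounds named here, nothing among the measured compounds separates one pyridyl from another, so compound 4 is expected to remain close to compound 3 and most probably again at the limit. For compound 4 the estimated step is a step that the limit leaves unreadable from compound 3 to compound 4. For compound 4 the expected value is 15000 nM, within a range from 4000 nM to 60000 nM.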

Compound 4, half-maximal inhibitory concentration: > 20000 nM
Compound 4: no number, only a limit; the forecaster's own chance of this, stated with the estimate: 70%; middle value at least 1.3-fold (0.12 log units) away from the limit.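

Compound 4, with 4-methylpyridin-3-yl on the amide-type nitrogen, also gives only a limit in this assay, so the result at this position is not confined to 3-methylpyridin-2-yl: the limit of > 20000 nM in this assay, at which 1 of the 4 values shown sits.

Set against the two fluorinated methylphenyl groups, this change gives an at least 11-fold higher number from compound 2 to compound 4 (1.07 log units; beyond the scatter) and an at least 6.2-fold higher number from compound 1 to compound 4 (0.79 log units; beyond the scatter), which places both pyridyl groups shown on the weaker side of both fluorinated methylphenyl groups. The step from compound 3 to compound 4 cannot be read: both ends are limits, and no order of the two pyridyl groups can be taken from them.

On these data alone, it remains open whether the ring nitrogen itself or the loss of fluorine accounts for the change, a question that a plain 2-methylphenyl group on the amide-type nitrogen would help to separate. Also open, as far as these compounds go, is whether a methylpyridyl group carrying a fluorine would return a readable number, which would show whether any pyridyl group can be tolerated at this position.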